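The source may report more compounds than this note shows. Statements on the series, on what has been measured and on what is new or still open speak of the compounds shown alone.

Working notes on the series.

Among the measured compounds shown here, compound 1 `NC1=NC2(CCOCC2)N(OCCCOc2cccc(Cl)c2)C(N)=N1` is the only member with a number: in an assay on isolated protein for inhibition of Dihydrofolate reductase (Homo sapiens), read by spectrophotometry, using NADPH, with stated times of 5 s and 6 min, tested at 50 uM (on this read-out higher numbers stand for a stronger effect at the one concentration tested and lower numbers for a weaker effect), compound 1 gives 85.8%. Compound 2 `NC1=NC2(CCOCC2)N(OCCCOc2ccc(F)cc2)C(N)=N1` has no result, its entry in this assay standing as "not determined" (no result reported). Compound 3 `Cc1ccc(OCCCON2C(N)=NC(N)=NC23CCOCC3)cc1` is in the same position: its entry in this assay is "not determined" (no result reported), so compound 3 has no number to stand on, and its neighbour without a number, compound 2, gives no anchor either. The only measured point in the set is therefore compound 1.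

Compound 4 `NC1=NC2(CCOCC2)N(OCCCOc2cccc(Cl)c2Cl)C(N)=N1` has not been measured in this assay. It differs from compound 3 in one place: 2,3-dichlorophenyl in place of 4-methylphenyl on an oxygen on a saturated carbon. With no number for compound 3, the size of this step cannot be read from the data. Compound 1 carries a chlorine-bearing phenyl and gives a high read-out, so compound 4, with two chlorines on its phenyl, is expected to land high as well; relative to compound 3 no direction can be stated beyond the scatter. The read-out of compound 4 in this assay is estimated at 85%, expected to fall between 65% and 97%.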

Compound 4, a percentage reported as inhibition, at one concentration (the size of the read-out at that concentration, not a potency): 89.8%
For compound 4 the middle estimate is 4.8 percentage points below the measured one; the measured number falls inside the stated range.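

Chloro in place of hydrogen on an aromatic carbon gives a number 4 percentage points higher from compound 1 to compound 4 (within the scatter) in this assay at the one concentration tested, so compound 1 and compound 4 cannot be told apart on this read-out. The step from 4-methylphenyl to 2,3-dichlorophenyl on an oxygen on a saturated carbon cannot be read, as compound 3 has no number. Nothing at hand bears on what lies behind these read-outs.

Still open, on these data alone, is how the read-out responds when the chlorines on the phenyl give way to a carboxylic acid, an amine or a nitrile, or when a longer chain links that ring to the shared core. As far as these compounds go, with both numbers taken at a single concentration, the potency of compound 1 and compound 4 also remains open.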